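The source may hold more compounds than are shown below. What is called first, only, known or untested is meant among the compounds shown, and "the series" means these compounds.

The three measured compounds share one core, seen in compound 2 `O=S(=O)(c1cc(Cl)cc(Cl)c1)c1cnc2c(F)cccc2c1-c1cccc(F)c1`, which in an ADME assay on microsomes from liver (Homo sapiens) for metabolic stability, tested at 2.5 uM (a higher number here means faster removal of the compound, a lower number slower removal), gives 1.08 mL/min, the highest of the three numbers. Compound 3 `N#Cc1cccc(S(=O)(=O)c2cnc3c(F)cccc3c2-c2cccc(F)c2)c1` gives 0.34 mL/min in this assay, and compound 1 `O=S(=O)(c1ccc(F)c(F)c1)c1cnc2c(F)cccc2c1-c1ccc(Cl)cc1` gives 0.28 mL/min. Among the compounds with values here, the only single-point step among them, a 3.2-fold lower number from compound 2 to compound 3 (0.50 log units; beyond the scatter), concerns the group on the sulfonyl sulfur and not the place changed in the new compound.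

Compound 4 `O=S(=O)(c1cc(Cl)cc(Cl)c1)c1cnc2c(F)cccc2c1-c1ccc(Cl)cc1` differs from compound 2 elsewhere: 4-chlorophenyl in place of 3-fluorophenyl on an aromatic carbon. Within the data shown here, no measured step isolates this exchange. Among the measured compounds shown here, compound 1 does carry a 4-chlorophenyl on the same aromatic carbon and has the lowest of the three numbers, but it also carries a different group on the sulfonyl sulfur, so its gap to compound 2 cannot be assigned to either change alone; no step between them is given, and only the two values themselves can be compared. For the measured compounds named here, with no direct precedent, the step of a 1.3-fold lower number from compound 2 to compound 4 (0.10 log units; within the scatter) is expected to be small, possibly within the scatter, leaning toward a lower number. Compound 4 is therefore estimated at 0.85 mL/min, with a range from 0.4 mL/min to 1.9 mL/min.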

Compound 4, intrinsic clearance in a liver preparation (reported as CLH), per the amount of preparation that the assay uses: 0.78 mL/min
Compound 4: the middle estimate sits 1.1-fold (0.04 log units) above what was measured; the measured number falls inside the stated range.
By their numbers in this assay, from the lowest: compounds 1 and 3 (each within the scatter of the next); then compounds 4 and 2 (each within the scatter of the next).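

In this assay the exchange of 3-fluorophenyl for 4-chlorophenyl on this aromatic carbon, opposite the ring nitrogen, gives a 1.4-fold lower number from compound 2 to compound 4 (0.14 log units; within the scatter) and so, with 3,5-dichlorophenyl on the sulfonyl sulfur, leaves the two groups indistinguishable in this read-out. Within the data shown here, the result also supplies the first step that holds 4-chlorophenyl in place and changes only the group on the sulfonyl sulfur, a 2.8-fold higher number from compound 1 to compound 4 (0.44 log units; beyond the scatter) for 3,5-dichlorophenyl in place of 3,4-difluorophenyl; together with a 3.2-fold lower number from compound 2 to compound 3 (0.50 log units; beyond the scatter) for 3-cyanophenyl in place of 3,5-dichlorophenyl, this places both steps beyond the scatter at the sulfonyl sulfur and none so far at this aromatic carbon. The data shown offer no explanation for any of these steps.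

The compounds shown carry this exchange only with 3,5-dichlorophenyl on the sulfonyl sulfur, so whether it stays as small alongside 3-cyanophenyl or 3,4-difluorophenyl remains open. Also open, from the compounds shown here alone, is how the number would respond at this aromatic carbon to a phenyl ring bearing a methoxy group, a carboxylic acid or an amine such as piperidine.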